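The compounds below may be only part of what the source reports. "The series", "measured", "known", "first", "only" and "open" are said of these compounds alone.

Going by the values given here, compound 3 `Cc1nc(S(C)(=O)=O)ccc1Oc1ncnc(OC2CCN(C(=S)OC(C)C)CC2)c1F` gives 47% in a functional assay on isolated protein for inhibition of Glucose-dependent insulinotropic receptor (Rattus norvegicus), read by HTRF and cAMP accumulation (a higher number here means a larger maximal response, a lower number a smaller maximal response), the lowest of the three values measured so far. Compound 1 `Cc1nc(S(C)(=O)=O)ccc1Oc1ncnc(OC2CCN(C(=O)OC(C)(C)C(F)(F)F)CC2)c1F` gives 79% in this assay, and compound 2 `Cc1nc(S(C)(=O)=O)ccc1Oc1ncnc(OC2CCN(C(=O)OC(C)(C)CF)CC2)c1F` gives 95% in this assay. Compound 4 `CCc1cnc(C(=O)N2CCC(Oc3ncnc(Oc4ccc(S(C)(=O)=O)nc4C)c3F)CC2)nc1` has not yet been measured; the change from compound 3 to compound 4 is a group of 10 heavy atoms (7 carbon, 2 nitrogen, 1 oxygen; one six-membered aromatic ring with 2 hetero atoms) in place of a group of 6 heavy atoms (4 carbon, 1 oxygen, 1 sulfur; no ring), on an amine nitrogen in a ring.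

Among the compounds with values here, two measured steps bear on this change, since both replace the same group of 6 heavy atoms on the ring nitrogen with a larger group: a number 32 percentage points lower from compound 1 to compound 3 (beyond the scatter) and a number 48 percentage points lower from compound 2 to compound 3 (beyond the scatter). Read in the reverse direction, both steps say that leaving the group of 6 heavy atoms for a larger group without a ring raised the maximal response by a large amount. The group that enters in compound 4 contains an aromatic ring and differs from both of those larger groups, so the size of the gain is uncertain, but a step upward beyond the scatter is expected because a number 32 percentage points lower from compound 1 to compound 3 (beyond the scatter) and a number 48 percentage points lower from compound 2 to compound 3 (beyond the scatter) both point that way. The expected step is a number 33 percentage points higher from compound 3 to compound 4 (beyond the scatter). Compound 4 is therefore estimated to reach 80% in this assay, with a range from 55% to 100%.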

Compound 4, largest response reached (reported as efficacy), in percent of the reference or control that the assay uses: 80%
For compound 4 middle estimate and measured number coincide at the digits printed; the measured number falls inside the stated range.
By their numbers in this assay, from the lowest: compound 3; then compounds 1 and 4 (each within the scatter of the next); then compound 2.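

In this assay, the ring nitrogen can carry a group containing a six-membered aromatic ring with 2 hetero atoms and still give a large maximal response: there is a number 33 percentage points higher from compound 3 to compound 4 (beyond the scatter), so the gain seen earlier is not limited to groups without a ring. On the carbonyl carbon, this assay does not separate 5-ethylpyrimidin-2-yl from 1-methyl-1-(trifluoromethyl)ethoxy, with a number 1 percentage points higher from compound 1 to compound 4 (within the scatter), whereas the group of 6 heavy atoms on the carbonyl carbon of compound 2 remains ahead of 5-ethylpyrimidin-2-yl, with a number 15 percentage points lower from compound 2 to compound 4 (beyond the scatter) as the measured step. No measurement available here explains these differences.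

As far as these compounds go, with a single ring-bearing group in the set, it remains open how much the ethyl on that ring contributes, and whether a methyl, a longer chain or an amine in its place would hold the response at this level. From the compounds shown here alone, it also remains open how much of the low value of compound 3 belongs to its sulfur, and whether an oxygen in that place would raise the response.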